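The compounds below may be only part of what the source reports. "The series", "measured", "known", "first", "only" and "open" are said of these compounds alone.

In an ADME assay on microsomes from liver (Homo sapiens) for metabolic stability, read by LC-MS, using NADPH, with a stated time of 10 min, tested at 0.5 uM (on this read-out higher numbers stand for a more stable compound and lower numbers for a less stable compound), compound 1 `CC(=O)Nc1cc(-c2ccc(OC[C@@](C)(N)CC(C)C)c(F)c2)ccn1` gives 91% and compound 2 `CC(=O)Nc1cc(-c2cc(F)c(OC[C@@H](N)CC(C)C)c(F)c2)ccn1` gives 90%, so these two values lie within the usual scatter of each other. Compound 3 `CC(=O)Nc1cc(-c2ccc(OC[C@@H](N)CC(C)C)c(F)c2)ccn1` differs from compound 2 in one place, with hydrogen in place of fluoro on an aromatic carbon. Within the data shown here, no measured pair shows what this swap does, so only a small drop, perhaps none beyond the scatter, is expected. The estimated change is a number 4 percentage points lower from compound 2 to compound 3 (within the scatter). For compound 3, the expected value is 86%, within an estimated range of 74% to 96%.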

Compound 3, percent of the compound remaining: 90%
The estimate for compound 3 lay 4 percentage points below the measured number; the range from low to high includes it.
By their numbers in this assay, from the lowest: compounds 2, 3 and 1 (each within the scatter of the next).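

In this assay, hydrogen in place of fluoro on the aromatic carbon ortho to the (2-amino-4-methylpentyl)oxy group can now be read directly: no change at the digits printed from compound 2 to compound 3 (within the scatter). 1-Amino-3-methylbutyl in place of 1-amino-1,3-dimethylbutyl gives a number 1 percentage points lower from compound 1 to compound 3 (within the scatter), so neither swap separates these compounds on this read-out. Nothing available explains this result.

Still open, as far as these compounds go, is whether a chloro or methoxy group on that aromatic carbon would stay within the scatter of compound 3. The same question applies to a carboxylic acid in place of the amine on the chain.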